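The source may report more compounds than this note shows. Statements on the series, on what has been measured and on what is new or still open speak of the compounds shown alone.

Measured so far in an ADME assay on LLC-MK2 cells (Macaca mulatta) for cytotoxicity, read by spectrophotometry and crystal violet staining, with a stated time of 4 days; a higher number here means that more compound is tolerated, a lower number that less compound is tolerated
- compound 1 `CC(C)n1ncc2c(C(=O)Nc3cccc(C(N)=O)c3)cc(-c3cccs3)nc21` gives 25000 nM
- compound 2 `CC(C)n1ncc2c(C(=O)Nc3cc(F)ccc3F)cc(-c3cccs3)nc21` gives 100000 nM
- compound 3 `CC(C)n1ncc2c(C(=O)Nc3ccc(F)c(S(N)(=O)=O)c3)cc(-c3cccs3)nc21` gives 50000 nM

Compound 3 lies within the usual scatter of each of the other two compounds, so it cannot be ranked against either of them. Compound 4 `CC(C)n1ncc2c(C(=O)Nc3cccc(S(N)(=O)=O)c3)cc(-c3cccs3)nc21` has yet to be measured. It differs from compound 3 in one place (hydrogen in place of fluoro on an aromatic carbon), with hydrogen in place of fluoro on an aromatic carbon, ortho to a sulfamoyl group.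

Among the compounds with values here, no measured step isolates this exchange. Within the data shown here, the only step available is a 4.0-fold higher number from compound 1 to compound 2 (0.60 log units; beyond the scatter) and that modest step replaces a whole group on the amide nitrogen, so it bears only loosely on the loss of a single fluoro. The expected step in this assay is a 1.3-fold lower number from compound 3 to compound 4 (0.10 log units; within the scatter) and it is expected to stay inside the scatter, slightly downward if anything. The estimated value for compound 4 is 40000 nM and the expected range runs from 18000 nM up to 90000 nM in this estimate.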

Compound 4, half-maximal cytotoxic concentration: 25000 nM
Beside the measured number, compound 4's estimate is 1.6-fold (0.20 log units) above it; low and high end bracket the measured number.
By their numbers in this assay, from the lowest: compounds 1, 4, 3 and 2 (each within the scatter of the next, the first and the last beyond it).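

In this assay the exchange of fluoro for hydrogen on this aromatic carbon, ortho to a sulfamoyl group, gives a 2.0-fold lower number from compound 3 to compound 4 (0.30 log units; within the scatter) and so has no effect that can be told apart from repeat-to-repeat variation. Sulfamoyl in place of carbamoyl gives no change at the digits printed from compound 1 to compound 4 (within the scatter) and these two groups cannot be separated here either, whereas replacing the whole 2,5-difluorophenyl group with 3-sulfamoylphenyl gives a 4.0-fold lower number from compound 2 to compound 4 (0.60 log units; beyond the scatter) and this is a real, though modest, difference. No measurement shown here explains these steps.

From the compounds shown here alone, whether a chloro, methyl or methoxy group on this same carbon would shift the number beyond the scatter stays open. So does the effect of an amine or a carboxylic acid in place of the sulfamoyl group.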